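Aryl in Place of Methyl on the Ring Nitrogen

A few compounds are considered here, and "the series" means these few. Any claim that something is new, unique, unknown or untested is made for them only; others in the source may bear on it.

Measured so far:
compound 1 `CN1CCN(CC(=O)Nc2nc3ccccc3[nH]2)CC1` 19.9%
compound 2 `CCN1CCN(CC(=O)Nc2nc3ccccc3[nH]2)CC1` 26.6%
compound 3 `O=C(CN1CCN(c2ccccn2)CC1)Nc1nc2ccccc2[nH]1` 40.9%

All three share one core and differ only in the group on the ring nitrogen. In a functional assay, read by spectrophotometry, with a stated time of 30 min, tested at 25 ug/mL (on this read-out lower numbers stand for a weaker effect and higher numbers for a stronger effect at the one concentration tested), compound 1 gives the lowest of the three numbers: compound 2 lies nearest, with a number 6.7 percentage points higher from compound 1 to compound 2 (within the scatter), and compound 3 furthest, with a number 21 percentage points higher from compound 1 to compound 3 (beyond the scatter). Compound 4 `COc1ccc(N2CCN(CC(=O)Nc3nc4ccccc4[nH]3)CC2)cc1` carries 4-methoxyphenyl in place of methyl on an amine nitrogen in a ring. Going by the values given here, the step that bears on it is the one to compound 3, where an aromatic ring replaced a small alkyl group and gave a number 21 percentage points higher from compound 1 to compound 3 (beyond the scatter), backed by a number 14.3 percentage points higher from compound 2 to compound 3 (beyond the scatter). A similar rise is expected here, roughly a number 20.1 percentage points higher from compound 1 to compound 4 (beyond the scatter), because a number 21 percentage points higher from compound 1 to compound 3 (beyond the scatter) points that way. Compound 4 is therefore estimated at 40%, between 25% and 55%.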

Compound 4, a percentage reported as activity, at one concentration (the size of the read-out at that concentration, not a potency): 13.3%
For compound 4 the middle estimate is 26.7 percentage points above the measured one; measured number below the stated range.
By their numbers in this assay, from the lowest: compounds 4, 1 and 2 (each within the scatter of the next, the first and the last beyond it); then compound 3.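

An aromatic ring on this ring nitrogen does not by itself raise the number: swapping methyl for 4-methoxyphenyl gives a number 6.6 percentage points lower from compound 1 to compound 4 (within the scatter). The kind of aromatic ring matters, as exchanging pyridin-2-yl for 4-methoxyphenyl gives a number 27.6 percentage points lower from compound 3 to compound 4 (beyond the scatter), and exchanging ethyl for 4-methoxyphenyl gives a number 13.3 percentage points lower from compound 2 to compound 4 (beyond the scatter). No measurement here explains the difference between these two aromatic groups. The compounds shown leave open how an unsubstituted phenyl, a pyridin-4-yl or a 4-hydroxyphenyl group would read on the same nitrogen. They also leave open whether the higher number of compound 3 belongs to pyridin-2-yl alone.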